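Bromophenyl on the ring nitrogen: an expected shift

This account rests on a few compounds, and the source may have more. Where it says the series, first, only, none or still open, it means among the compounds named here.

Compound 1 `CCCn1c(=O)[nH]c2nc(-c3ccc(S(=O)(=O)N4CCN(Cc5cccc(C)c5)CC4)cc3)[nH]c2c1=O` in an assay on CHO cells for displacement of a labelled ligand from adenosine receptor A1 (Homo sapiens), read by scintillation counting, with a stated time of 90 min, in the presence of a further agent that is not named here; a higher number here means a weaker inhibitor, a lower number a stronger inhibitor: 795 nM
Compound 2 `CCCn1c(=O)[nH]c2nc(-c3ccc(S(=O)(=O)N4CCN(C)CC4)cc3)[nH]c2c1=O` in this assay: 334 nM

Compound 2 gives the lower of the two measured numbers in this assay; its nearest neighbour, compound 1, lies a 2.4-fold lower number from compound 1 to compound 2 (0.38 log units; beyond the scatter) away, a gap beyond the scatter. Compound 3 `CCCn1c(=O)[nH]c2nc(-c3ccc(S(=O)(=O)N4CCN(c5cccc(Br)c5)CC4)cc3)[nH]c2c1=O` has not yet been measured. It differs from compound 2 by 3-bromophenyl in place of methyl on an amine nitrogen in a ring; the group that enters is attached directly to the ring nitrogen, not through a saturated chain carbon as in compound 1. Among the measured compounds shown here, the only measured step that bears on this change is the one from compound 1 to compound 2, where the loss of an aromatic ring from this position lowered the number by a 2.4-fold lower number from compound 1 to compound 2 (0.38 log units; beyond the scatter). Reading that step in reverse, the return of an aromatic ring in compound 3 is expected to raise the number again by a modest amount, a 2.1-fold higher number from compound 2 to compound 3 (0.32 log units; beyond the scatter), with the direct attachment and the bromine leaving room for a wider range. Compound 3 is therefore estimated at 700 nM, between 250 nM and 2000 nM.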

Compound 3, inhibition constant: > 1000 nM
Compound 3 was reported as a limit; the forecaster's own chance of this, stated with the estimate: 5%; at least 1.4-fold (0.15 log units) between middle value and limit.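

Compound 3 is reported in this assay only as a limit, not as a number: the limit of > 1000 nM in this assay, at which 1 of the 3 values shown sits.

Even so, putting 3-bromophenyl in place of methyl gives an at least 2.9-fold higher number from compound 2 to compound 3 (0.47 log units; beyond the scatter), so an aromatic ring attached directly to the amine nitrogen in a ring, with no saturated chain carbon, goes with a higher number, as the 3-methylbenzyl group does, and among the three compounds the methyl compound stands lowest. The comparison with the benzyl group says much less: exchanging 3-methylbenzyl for 3-bromophenyl gives an at least 1.2-fold higher number from compound 1 to compound 3 (0.09 log units; that floor lies within the scatter), so the result does not show whether removing the chain carbon and changing the ring substituent make any difference at all.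

The compounds shown leave open how far the number of compound 3 lies beyond its limit, and whether the bromine contributes to the change, which a plain phenyl group on the same nitrogen would address. They also leave open whether an aromatic ring is needed for the rise at all, which a longer chain such as butyl or a bare hydrogen on this nitrogen would test.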